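Adding a second bromo to compound 2

The source may hold more compounds than are shown below. What is called first, only, known or untested is meant among the compounds shown, and "the series" means these compounds.

In a functional assay on P388 cells (Mus musculus) for cytotoxicity (on this read-out lower numbers stand for stronger inhibition and higher numbers for weaker inhibition), compound 1 `Brc1ccc2c(-c3nc(-c4c[nH]c5ccccc45)c[nH]3)c[nH]c2c1` gives 4500 nM and compound 2 `Brc1ccc2c(-c3c[nH]c(-c4c[nH]c5ccccc45)n3)c[nH]c2c1` gives 4500 nM so the two stand level. Compound 3 `Brc1ccc2c(-c3c[nH]c(-c4c[nH]c5cc(Br)ccc45)n3)c[nH]c2c1` differs from compound 2 by one change bromo in place of hydrogen on an aromatic carbon with bromo in place of hydrogen on an aromatic carbon. Within the data shown here, no measured pair shows what such a change does, so any expectation here is loose. The expected 1.8-fold lower number from compound 2 to compound 3 (0.26 log units; within the scatter) is a small move toward a lower number in this assay and stays within the scatter. Compound 3 is estimated at 2500 nM with a range from 800 nM to 8000 nM for now.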

Compound 3, half-maximal inhibitory concentration: 4500 nM
Compound 3: middle estimate off by 1.8-fold (0.26 log units), on the low side, and the stated range covers the measured number.
By their numbers in this assay, from the lowest: compounds 1, 2 and 3 (each within the scatter of the next).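

In this assay, bromo in place of hydrogen on an aromatic carbon gives no change at the digits printed from compound 2 to compound 3 (within the scatter), and the same kind of change gives no change at the digits printed from compound 1 to compound 3 (within the scatter). Among these compounds, this is the first measured sign that this position, on a six-membered aromatic ring of carbon only, can carry a second bromo without a visible shift in the read-out. Nothing in the available data explains this result.

Going by these compounds, whether an amine or a carboxylic acid at this position would move the number remains open. So does whether chloro would behave as bromo does here.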